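Replacing the 4-hydroxypiperidin-1-yl group of compound 3 with chloro

The compounds below may be only part of what the source reports. "The series", "measured", "known", "first", "only" and "open" are said of these compounds alone.

In a functional assay on MGC-803 cells (Homo sapiens) for cytotoxicity, read by MTT assay, with a stated time of 48 h (on this read-out lower numbers stand for stronger inhibition and higher numbers for weaker inhibition), compound 1 `CC(=O)Oc1ccccc1C1CC(C)=NN1C(=O)CN(C(C)C)C(C)C` gives 20100 nM, compound 2 `CC(=O)Oc1ccccc1C1CC(C)=NN1C(=O)CN1CCCCC1` gives 4890 nM and compound 3 `CC(=O)Oc1ccccc1C1CC(C)=NN1C(=O)CN1CCC(O)CC1` gives 3510 nM. Compound 3 belongs to the low pair of these numbers: a 1.4-fold lower number from compound 2 to compound 3 (0.14 log units; within the scatter) is small, while a 5.7-fold lower number from compound 1 to compound 3 (0.76 log units; beyond the scatter) and a 4.1-fold lower number from compound 1 to compound 2 (0.61 log units; beyond the scatter) are modest. Unmeasured compound 4 `CC(=O)Oc1ccccc1C1CC(C)=NN1C(=O)CCl` has chloro in place of 4-hydroxypiperidin-1-yl on a saturated chain carbon bound to a carbonyl carbon. The measured steps only exchange one amine for another or add hydroxy, so they offer a loose guide, and none removes the amine. The expected result is a 1.7-fold higher number from compound 3 to compound 4 (0.23 log units; within the scatter), which is no firm shift. For compound 4, the estimated value is 6000 nM, within an expected range of 1500 nM to 25000 nM.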

Compound 4, half-maximal inhibitory concentration: 3010 nM
The estimate for compound 4 lay 2.0-fold (0.30 log units) above the measured number; the measured number falls inside the stated range.
By their numbers in this assay, from the lowest: compounds 4, 3 and 2 (each within the scatter of the next); then compound 1.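

In this assay the amine at this position proves dispensable: chloro, a single heavy atom with no ring, matches 4-hydroxypiperidin-1-yl (a 1.2-fold lower number from compound 3 to compound 4 (0.07 log units; within the scatter)) and piperidin-1-yl (a 1.6-fold lower number from compound 2 to compound 4 (0.21 log units; within the scatter)). Only diisopropylamino stands apart from chloro (a 6.7-fold lower number from compound 1 to compound 4 (0.82 log units; beyond the scatter)). Nothing measured here explains these results. Still open, as far as these compounds go, is whether morpholin-4-yl, or bromo on the same saturated chain carbon, would group with compounds 2, 3 and 4 or with compound 1.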